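Aryl substituent steps on the bromomethyl lactone series

The source may report more compounds than this note shows. Statements on the series, on what has been measured and on what is new or still open speak of the compounds shown alone.

Of the compounds shown here, three on one core have been measured in a functional assay on A-431 cells (Homo sapiens) for antiproliferative activity, read by sulforhodamine B assay, with a stated time of 72 h; a higher number here means a weaker inhibitor, a lower number a stronger inhibitor. Compound 1 `C=C1CC(CBr)(c2ccccc2)OC1=O` gives 1480 nM. Compound 2 `C=C1CC(CBr)(c2ccc(OC)cc2)OC1=O` gives 4200 nM, and compound 3 `C=C1CC(CBr)(c2ccc(F)cc2)OC1=O` gives 800 nM. Compound 3 has the lowest of the three numbers, but the step that reaches it from the unsubstituted aryl (a 1.9-fold lower number from compound 1 to compound 3 (0.27 log units; within the scatter)) lies within the scatter, so those two cannot be ordered; only compound 2 stands clearly apart (a 5.3-fold lower number from compound 2 to compound 3 (0.72 log units; beyond the scatter)). Methoxy in place of hydrogen moved the number up (a 2.8-fold higher number from compound 1 to compound 2 (0.45 log units; beyond the scatter)).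

Compound 4 `C=C1CC(CBr)(c2ccc(C(F)(F)F)cc2)OC1=O` differs from compound 3 by trifluoromethyl in place of fluoro on an aromatic carbon. Going by the values given here, no measured step exchanges fluoro for trifluoromethyl, so the bearing of the known steps is indirect: fluoro for hydrogen changed little, methoxy for hydrogen raised the number modestly. On that basis the number for compound 4 is expected to rise by about a 1.9-fold higher number from compound 3 to compound 4 (0.27 log units; within the scatter) in this assay. The estimate for compound 4 is therefore 1500 nM, with a range from 600 nM to 4000 nM.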

Compound 4, half-maximal inhibitory concentration: 1010 nM
Estimate against measurement, compound 4: 1.5-fold (0.17 log units) above; the range from low to high includes it.
By their numbers in this assay, from the lowest: compounds 3, 4 and 1 (each within the scatter of the next); then compound 2.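

In this assay, at this aromatic carbon, trifluoromethyl in place of fluoro puts 4 heavy atoms where 1 stood, yet the step stays within the scatter (a 1.3-fold higher number from compound 3 to compound 4 (0.10 log units; within the scatter)), and trifluoromethyl in place of hydrogen does the same (a 1.5-fold lower number from compound 1 to compound 4 (0.17 log units; within the scatter)). Trifluoromethyl in place of methoxy is the one new step beyond the scatter (a 4.2-fold lower number from compound 2 to compound 4 (0.62 log units; beyond the scatter)), so among the four substituent states only the methoxy of compound 2 stands apart, while compound 1, compound 3 and compound 4 cannot be ordered. Nothing available explains this difference.

On these data alone, whether an amine or a carboxylic acid at this place would part from compound 1, compound 3 and compound 4 as methoxy does remains open. As far as these compounds go, all four compounds carry bromomethyl, so the effect of a longer chain there is also open.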